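The source may report more compounds than this note shows. Statements on the series, on what has been measured and on what is new or still open speak of the compounds shown alone.

In a functional assay on the whole organism for agonist activity, with Mus musculus as the target (a higher number here means that more compound is needed for the effect, a lower number that less compound is needed), compound 1 `CC(=O)N(C)C(C)C#CCn1ccnc1` gives 3 mg/kg. Compound 2 `CC(=O)NCC#CCn1ccnc1` returns no number, only a limit of the assay, > 100 mg/kg. Compound 3 `CC(=O)N(C)CC#CCn1ccnc1` departs from compound 2 in one place, with methyl in place of hydrogen on an amide-type nitrogen. Going by the values given here, no measured pair isolates this change, so any expectation rests on indirect evidence. Compound 1 also carries a methyl on its amide-type nitrogen and gives 3 mg/kg, although it differs from compound 2 elsewhere as well. That value points towards less compound being needed once the methyl is present. The expected step is an at least 4.0-fold lower number from compound 2 to compound 3 (0.60 log units; beyond the scatter), a move beyond the scatter towards a lower dose. For compound 3, the estimated value is 25 mg/kg, with an expected range from 6 mg/kg to 100 mg/kg.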

Compound 3, dose for half-maximal effect: 1.4 mg/kg
Estimate against measurement, compound 3: 18-fold (1.25 log units) above; measured number below the stated range.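

In this assay, methyl in place of hydrogen on the amide-type nitrogen now stands as an isolated change, and it gives an at least 71-fold lower number from compound 2 to compound 3 (1.85 log units; beyond the scatter), so this single carbon separates a compound with a measurable dose from one without. The reading for compound 2 is a limit and not a number, so this step has a floor but no known size: the limit of > 100 mg/kg in this assay, at which 1 of the 3 values shown sits. Hydrogen in place of methyl on the saturated chain carbon bound to an amide-type nitrogen and a triple-bonded carbon gives a 2.1-fold lower number from compound 1 to compound 3 (0.33 log units; beyond the scatter), a modest step, which shows that the chain methyl is not needed for activity in this assay.

Going by these compounds, whether an ethyl on the amide-type nitrogen would keep a dose in this range remains open. So does the outcome of placing an ethyl, rather than a methyl, on the saturated chain carbon.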